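Acid to Amine on the Side Chain of a Shared Core

The compounds below may be only part of what the source reports. "The series", "measured", "known", "first", "only" and "open" are said of these compounds alone.

For the measured compounds named here, compound 2 `CC(C)C[C@@H]1NC(=O)[C@H](CCC(=O)O)NC1=O` gives 97.8% in a functional assay, tested at 2.5 mM (a lower number here means less inhibition, a higher number more inhibition at the concentration tested (going by the name of the read-out)), the higher of the two numbers known. Its nearest neighbour, compound 1 `CC(C)C[C@@H]1NC(=O)[C@H](Cc2cnc[nH]2)NC1=O`, gives 83.9% in this assay, and the step runs a number 13.9 percentage points higher from compound 1 to compound 2 (beyond the scatter). Compound 3 `CC(C)C[C@@H]1NC(=O)[C@H](CCCCN)NC1=O` differs from compound 2 by 2-aminoethyl in place of carboxy on a saturated chain carbon, two bonds along the chain from a saturated ring carbon. Going by the values given here, no measured step exchanges an acid for an amine, and the single known step of a number 13.9 percentage points higher from compound 1 to compound 2 (beyond the scatter) concerns another change, so it is only a weak guide. Because compound 2 already stands at 97.8%, a step of a number 12.8 percentage points lower from compound 2 to compound 3 (beyond the scatter) is expected, downward or within the scatter. Compound 3 is estimated at 85%, between 60% and 100%.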

Compound 3, a percentage reported as inhibition, at one concentration (the size of the read-out at that concentration, not a potency): 96%
Estimate against measurement, compound 3: 11 percentage points below; measured number inside the range.
By their numbers in this assay, from the lowest: compound 1; then compounds 3 and 2 (each within the scatter of the next).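

At this position, changing from 2-carboxyethyl to 4-aminobutyl gives in this assay a number 1.8 percentage points lower from compound 2 to compound 3 (within the scatter) and so does not separate the carboxylic acid from the amine. The other step, a number 12.1 percentage points higher from compound 1 to compound 3 (beyond the scatter), shows that 4-aminobutyl, like 2-carboxyethyl, stands apart from the 1H-imidazol-5-yl side chain of compound 1. No available evidence bears on the reason for this result.

As far as these compounds go, what a plain butyl chain, with neither an amine nor a carboxylic acid at its end, would give stays open. Also open, from the compounds shown here alone, is whether a shorter amine chain would match 4-aminobutyl.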